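A Smaller Group on the Pyrazole Nitrogen

The source may report more compounds than this note shows. Statements on the series, on what has been measured and on what is new or still open speak of the compounds shown alone.

Three compounds share one core and differ only in the group hanging from it. Compound 1 `Cc1c(Nc2nc(N)c3c(C#N)c(N4CCC[C@H]4C)n(C)c3n2)cnn1CC(C)(C)O` gives 280 nM in an assay on HEK293 cells for inhibition of Leucine-rich repeat serine/threonine-protein kinase 2 (Homo sapiens), with a stated time of 48 h; a higher number here means a weaker inhibitor, a lower number a stronger inhibitor. Compound 2 `C[C@@H]1CCCN1c1c(C#N)c2c(N)nc(Nc3cn(C)nc3C(F)(F)F)nc2n1C` gives 910 nM. Compound 3 `Cc1c(Nc2nc(N)c3c(C#N)c(N4CCC[C@H]4C)n(C)c3n2)cnn1C1COC1` gives 300 nM; its number is the second highest of the three, close to compound 1 and clearly apart from compound 2, as the steps of a 1.1-fold higher number from compound 1 to compound 3 (0.03 log units; within the scatter) and a 3.0-fold lower number from compound 2 to compound 3 (0.48 log units; beyond the scatter) show.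

Compound 4 `Cc1c(Nc2nc(N)c3c(C#N)c(N4CCC[C@H]4C)n(C)c3n2)cnn1C` has not yet been measured. It differs from compound 3 in one place: methyl in place of oxetan-3-yl on an aromatic nitrogen.

Going by the values given here, only one measured step speaks directly to a change on that same aromatic nitrogen: a 1.1-fold higher number from compound 1 to compound 3 (0.03 log units; within the scatter), in which swapping one group for another at that position left the number essentially unchanged. The step of a 3.0-fold lower number from compound 2 to compound 3 (0.48 log units; beyond the scatter) alters two parts of the pyrazole at once, so it cannot be credited to the nitrogen substituent alone. On this basis the expected step from compound 3 to compound 4 is no change at the digits printed from compound 3 to compound 4 (within the scatter), that is, no change beyond the scatter in either direction. The estimate for compound 4 is therefore 300 nM, with a range from 150 nM to 650 nM.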

Compound 4, half-maximal inhibitory concentration: 310 nM
Estimate against measurement, compound 4: 1.0-fold (0.01 log units) below, and the stated range covers the measured number.
By their numbers in this assay, from the lowest: compounds 1, 3 and 4 (each within the scatter of the next); then compound 2.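

Going by these compounds alone, until now only two larger groups had been compared on this aromatic nitrogen, and a 1.0-fold higher number from compound 3 to compound 4 (0.01 log units; within the scatter) shows that methyl, a single carbon with no ring and no hydrogen-bond acceptor, lies within the scatter of the oxetan-3-yl it replaces. The comparison with the hydroxy-bearing chain of compound 1 gives the same reading, since a 1.1-fold higher number from compound 1 to compound 4 (0.04 log units; within the scatter) is also within the scatter, so the groups on this nitrogen in compounds 1, 3 and 4 are not told apart by these numbers. Compound 2 also carries methyl on its pyrazole nitrogen, yet a 2.9-fold lower number from compound 2 to compound 4 (0.47 log units; beyond the scatter) is beyond the scatter, which places this gap in the remaining difference between 1,5-dimethyl-1H-pyrazol-4-yl and 1-methyl-3-(trifluoromethyl)-1H-pyrazol-4-yl rather than in the nitrogen group.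

Nothing shown here offers a reason why these three nitrogen groups give such similar numbers. From the compounds shown here alone, it also remains open whether a chain ending in an amine or a carboxylic acid on that nitrogen would read the same, and whether the methyl or the trifluoromethyl on the pyrazole carbons accounts for the gap to compound 2.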